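The source may report more compounds than this note shows. Statements on the series, on what has been measured and on what is new or still open speak of the compounds shown alone.

Measured so far:
- compound 1 `CC[C@H]1CN(c2ncc(C#N)cc2Cl)CCN1C1CCN(Cc2ccc(Cl)cc2F)CC1`; in an assay on isolated protein for binding affinity to C-X-C chemokine receptor type 3 (Homo sapiens) (on this read-out lower numbers stand for stronger inhibition and higher numbers for weaker inhibition), compound 1 gives 50.5 nM
- compound 2 `CC[C@H]1CN(c2ncc(-c3noc(=O)[nH]3)cc2Cl)CCN1C1CCN(Cc2ccc(Cl)cc2F)CC1`; in this assay compound 2 gives 760 nM

Among the measured compounds shown here, compound 2 stands at the higher of the two numbers, and the one measured step, a 15-fold higher number from compound 1 to compound 2 (1.18 log units; beyond the scatter), shows how much was lost when the nitrile of compound 1 gave way to the six-atom ring of compound 2. The next step leads to compound 3 `CC[C@H]1CN(c2ncc(-c3nnco3)cc2Cl)CCN1C1CCN(Cc2ccc(Cl)cc2F)CC1`, where (a group of 5 heavy atoms (2 carbon, 2 nitrogen, 1 oxygen; one five-membered aromatic ring with 3 hetero atoms) in place of a group of 6 heavy atoms (2 carbon, 2 nitrogen, 2 oxygen; one five-membered aromatic ring with 3 hetero atoms), on an aromatic carbon). For the measured compounds named here, only the step from compound 1 to compound 2 bears on this position, and it was large. Compound 3 keeps a five-membered aromatic ring with three hetero atoms yet sheds the hydrogen-bond donor and the double bond outside aromatic rings, so it sits between the two measured groups in what it carries. Compound 3 is therefore expected to land between them, with a 3.0-fold lower number from compound 2 to compound 3 (0.48 log units; beyond the scatter) as the expected change. The estimate for compound 3 in this assay is 250 nM, within 80 nM to 800 nM.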

Compound 3, half-maximal inhibitory concentration: 1.4 nM
The estimate for compound 3 lay 180-fold (2.25 log units) above the measured number; measured number outside the range, below it.
By their numbers in this assay, from the lowest: compound 3; then compound 1; then compound 2.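

In this assay, the change to 1,3,4-oxadiazol-2-yl brings a 540-fold lower number from compound 2 to compound 3 (2.73 log units; beyond the scatter) even though the group that leaves also holds a five-membered aromatic ring with 3 hetero atoms, so at this position the presence of such a ring does not by itself settle the outcome. The same group also improves on the nitrile, giving a 36-fold lower number from compound 1 to compound 3 (1.56 log units; beyond the scatter), which shows that the earlier loss was no general penalty for putting a five-membered ring in place of the nitrile. Nothing available explains why two such similar rings differ so widely.

From the compounds shown here alone, it remains open whether a 1,3,4-thiadiazol-2-yl group, with sulfur in place of the ring oxygen, would keep this low number. The effect of a methyl group on the ring's free carbon is equally unknown.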